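Working notes: cyclohexyl to anilino on a carbonyl carbon

A few compounds are considered here, and "the series" means these few. Any claim that something is new, unique, unknown or untested is made for them only; others in the source may bear on it.

- compound 1 `CC(C)[C@H](NC(=O)c1ccccc1)C(=O)N1CCC[C@H]1C(=O)N[C@@H](CCCNC(=N)N)C(=O)CF`: 660 nM
- compound 2 `CC(C)[C@H](NC(=O)c1ccc(Br)cc1)C(=O)N1CCC[C@H]1C(=O)N[C@@H](CCCNC(=N)N)C(=O)CF`: 130 nM
- compound 3 `CC(C)[C@H](NC(=O)C1CCCCC1)C(=O)N1CCC[C@H]1C(=O)N[C@@H](CCCNC(=N)N)C(=O)CF`: 940 nM

In a functional assay on OCI-Ly3 cells (Homo sapiens) for inhibition, read by CellTiter-Glo, with stated times of 48 h and 96 h (on this read-out higher numbers stand for weaker inhibition of growth and lower numbers for stronger inhibition of growth), compound 3 gives 940 nM, level with compound 1 within the scatter: a 1.4-fold higher number from compound 1 to compound 3 (0.15 log units; within the scatter). Compound 2 stands apart: a 7.2-fold higher number from compound 2 to compound 3 (0.86 log units; beyond the scatter). Compound 4 `CC(C)[C@H](NC(=O)Nc1ccccc1)C(=O)N1CCC[C@H]1C(=O)N[C@@H](CCCNC(=N)N)C(=O)CF` carries anilino in place of cyclohexyl on a carbonyl carbon. The closest measured change is a 1.4-fold higher number from compound 1 to compound 3 (0.15 log units; within the scatter), which also swaps a phenyl and a cyclohexyl. The bromo gain, a 5.1-fold lower number from compound 1 to compound 2 (0.71 log units; beyond the scatter), does not apply, as compound 4 carries no bromo. Among the compounds with values here, no measured step covers the entering nitrogen. A small step to a lower number, within the scatter, is therefore expected: a 1.4-fold lower number from compound 3 to compound 4 (0.16 log units; within the scatter). The estimate for compound 4 is 650 nM, with an expected range of 200 nM to 1800 nM.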

Compound 4, concentration for 50% growth inhibition: 1520 nM
Compound 4: the middle estimate sits 2.3-fold (0.37 log units) below what was measured, within the range that was stated.
By their numbers in this assay, from the lowest: compound 2; then compounds 1, 3 and 4 (each within the scatter of the next, the first and the last beyond it).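

In this assay, anilino on this carbonyl carbon stays level with cyclohexyl, with a 1.6-fold higher number from compound 3 to compound 4 (0.21 log units; within the scatter), yet the entering nitrogen separates it from the directly attached phenyl, with a 2.3-fold higher number from compound 1 to compound 4 (0.36 log units; beyond the scatter). Within the data shown here, the 4-bromophenyl now stands furthest from anilino, with a 12-fold higher number from compound 2 to compound 4 (1.07 log units; beyond the scatter) as the largest step so far. No measurement bears on why this nitrogen shifts the number.

Open, going by these compounds, is whether 4-bromoanilino would carry the bromo step over to the anilino compounds. Cyclohexylamino would test the entering nitrogen without a change of ring.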